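Carbonyl substituent change from compound 2 to compound 3

The source may report more compounds than this note shows. Statements on the series, on what has been measured and on what is new or still open speak of the compounds shown alone.

The shared core carries a two-carbon chain ending in a carbonyl-bearing nitrogen. Compound 1 `COc1ccc(/C(=C(/CCNC(=O)Oc2ccccc2)c2ccccc2)c2ccccc2)cc1` is recorded in a functional assay on MCF7 cells (Homo sapiens) for cytotoxicity, read by MTT assay, with a stated time of 72 h (on this read-out higher numbers stand for weaker inhibition and lower numbers for stronger inhibition), as "not active" (no number reported). Compound 2 `COc1ccc(/C(=C(/CCNC(=O)N2CCOCC2)c2ccccc2)c2ccccc2)cc1` gives in this assay only a limit, > 50000 nM, and not a number. Among the compounds with values here, compound 2 thus stands at the limit of > 50000 nM in this assay, at which 1 of the 2 values shown sits; no step between measured compounds can be drawn from these two entries, which show only that neither reached a measurable value.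

Compound 3 `CCN(CC)C(=O)NCC/C(=C(\c1ccccc1)c1ccc(OC)cc1)c1ccccc1` differs from compound 2 by diethylamino in place of morpholin-4-yl on a carbonyl carbon. Within the data shown here, with no measured step available, the expectation rests on the position of compound 2 alone, and compound 3 is expected to remain at the limit, with no step beyond the scatter in either direction. The step is expected to be a step that the limit leaves unreadable from compound 2 to compound 3. Compound 3 is accordingly estimated at 70000 nM, in the range 20000 nM to 250000 nM, most likely reported again as a limit.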

Compound 3, half-maximal inhibitory concentration: > 50000 nM
Compound 3: a limit, no number; the forecaster's own chance of this, stated with the estimate: 75%; the middle value lies beyond the limit too.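

In this assay, within the data shown here, compound 2 and compound 3 both give only limits and not numbers, so no step between them can be read. The compounds shown leave open whether diethylamino in place of morpholin-4-yl on the carbonyl carbon changes cytotoxicity at all.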